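A few compounds are considered here, and "the series" means these few. Any claim that something is new, unique, unknown or untested is made for them only; others in the source may bear on it.

In a functional assay on CWR22R cells (Homo sapiens) for antiproliferative activity, read by CCK-8 assay, with a stated time of 6 days (a higher number here means a weaker inhibitor, a lower number a stronger inhibitor), measured so far:
- Compound 1 `C[C@@H](Cn1ccc(-c2ccc(C#N)c(Cl)c2)n1)Nc1ccccc1`: > 30000 nM
- Compound 2 `C[C@@H](Cn1ccc(-c2ccc(C#N)c(Cl)c2)n1)Nc1ccccn1`: > 30000 nM

Both entries are limits of the assay and not numbers, so compound 2 has no numerical position in the series. The evidence so far is the limit of > 30000 nM in this assay, at which 2 of the 2 values shown sit.

The next change leads to compound 3 `C[C@@H](Cn1ccc(-c2ccc(C#N)c(Cl)c2)n1)Nc1cncnc1`: pyrimidin-5-yl in place of pyridin-2-yl on an amine nitrogen. Going by the values given here, the one measured step that bears on it is a step that the two limits leave unreadable from compound 1 to compound 2, made at the same place on the amine nitrogen. Since a step that the two limits leave unreadable from compound 1 to compound 2 offers no size to carry over, no step beyond the scatter is expected in this assay, in either direction. The expected change is a number no higher from compound 2 to compound 3 (the limit leaves the size open). For compound 3 the estimated value is 30000 nM, with an expected range of 12000 nM to 60000 nM.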

Compound 3, half-maximal inhibitory concentration: > 30000 nM
Compound 3: a limit, no number (the forecaster's own chance of this, stated with the estimate: 85%); the middle value lies on the limit itself.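

In this assay compound 3 gives > 30000 nM, a limit and not a number. No step among compound 1, compound 2 and compound 3 can be read: the limit of > 30000 nM in this assay, at which 3 of the 3 values shown sit.

The compounds shown leave open whether any of these groups on the amine nitrogen differs from the others in this assay.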